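Putting 1H-tetrazol-5-yl in place of dimethylcarbamoyl

This account rests on a few compounds, and the source may have more. Where it says the series, first, only, none or still open, it means among the compounds named here.

- Compound 1 `c1ccc(Oc2ccc(-c3nc4cccnc4n3C3CCCC3)cc2)cc1`: > 10000 nM, a limit of the assay
- Compound 2 `O=C(NC1CC1)c1ccc(-c2nc3cccnc3n2C2CCCC2)cc1`: 115 nM
- Compound 3 `CN(C)C(=O)c1ccc(-c2nc3cccnc3n2C2CCCC2)cc1`: 520 nM

In a functional assay on MDA-MB-231 cells (Homo sapiens) for cytotoxicity, read by MTT assay, with a stated time of 24 h (on this read-out lower numbers stand for stronger inhibition and higher numbers for weaker inhibition), compound 3 gives 520 nM, the higher of the two actual numbers, and its nearest neighbour is compound 2 at 115 nM. Compound 1 is reported only as a limit, > 10000 nM.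

Compound 4 `c1cnc2c(c1)nc(-c1ccc(-c3nnn[nH]3)cc1)n2C1CCCC1` carries 1H-tetrazol-5-yl in place of dimethylcarbamoyl on an aromatic carbon, para to a large group: 1H-tetrazol-5-yl in place of dimethylcarbamoyl on an aromatic carbon.

Within the data shown here, three measured steps bear on this place. Replacing phenoxy gave two large steps, an at least 86-fold lower number from compound 1 to compound 2 (1.93 log units; beyond the scatter) and an at least 19-fold lower number from compound 1 to compound 3 (1.28 log units; beyond the scatter). Changing only the group on the carbonyl carbon gave a modest one, a 4.5-fold higher number from compound 2 to compound 3 (0.66 log units; beyond the scatter). None of them tests the new group, so the expectation is loose. Among the measured compounds shown here, the group at this place clearly matters, and the only compound without a carbonyl group is the poor end of an at least 19-fold lower number from compound 1 to compound 3 (1.28 log units; beyond the scatter). A modest rise in the number is therefore expected in this assay. The expected step is a 2.9-fold higher number from compound 3 to compound 4 (0.46 log units; beyond the scatter). Compound 4 is estimated at 1500 nM, with an expected range of 200 nM to 9000 nM.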

Compound 4, half-maximal inhibitory concentration: 765 nM
Compound 4: the middle estimate sits 2.0-fold (0.29 log units) above what was measured; low and high end bracket the measured number.
By their numbers in this assay, from the lowest: compound 2; then compounds 3 and 4 (each within the scatter of the next). At a limit, above all of these: compound 1.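

In this assay, a carbonyl proves not to be needed at this place: 1H-tetrazol-5-yl has none, yet it gives a 1.5-fold higher number from compound 3 to compound 4 (0.17 log units; within the scatter), so it cannot be told apart from dimethylcarbamoyl. Cyclopropylcarbamoyl still holds the lowest number among these groups, with a 6.7-fold higher number from compound 2 to compound 4 (0.82 log units; beyond the scatter). Phenoxy now stands apart from all three other groups, and the new comparison with it, an at least 13-fold lower number from compound 1 to compound 4 (1.11 log units; beyond the scatter), is read against a limit and not a number: the limit of > 10000 nM in this assay, at which 1 of the 4 values shown sits.

The compounds shown leave open how a carboxylic acid or a primary amide would compare at this place with 1H-tetrazol-5-yl. They also leave open whether the lower number of compound 2 depends on the cyclopropyl ring or on the amide hydrogen, a question that a methylamino group on the carbonyl carbon could help to separate.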